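The compounds below may be only part of what the source reports. "The series", "measured", "known", "first", "only" and "open" are said of these compounds alone.

Compound 1 `CCN(Cc1cccs1)C(=O)COc1ccc(C)cc1` is the anchor of this small set. In an assay on HEK293 cells for agonist activity at transient receptor potential cation channel subfamily M member 8 (Homo sapiens), read by fluorescence and calcium flux, with a stated time of 15 min (on this read-out lower numbers stand for an effect already at smaller amounts and higher numbers for an effect only at larger amounts of compound), compound 1 gives 8 nM, the lowest of the two numbers reported. Compound 3 `CCN(Cc1cccs1)C(=O)COc1ccc(C(F)(F)F)cc1`, which carries trifluoromethyl in place of methyl on an aromatic carbon, gives 236 nM in this assay, and the step of a 30-fold higher number from compound 1 to compound 3 (1.47 log units; beyond the scatter) is a large loss. Compound 2 `CCN(C(=O)COc1ccc(C)cc1)C(C)c1cccs1` differs from compound 1 at the chain carbon attached to the amide nitrogen. In this assay compound 2 is reported only as "not active" (no number reported), with no number given.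

Compound 4 `Cc1ccc(OCC(=O)N(Cc2cccs2)C2COC2)cc1` has not yet been measured. It differs from compound 1 by oxetan-3-yl in place of ethyl on an amide-type nitrogen. Within the data shown here, no measured step touches this position: the one quantified step concerns the aromatic ring, and compound 2 shows only that a change at the amide nitrogen's neighbour can abolish the signal, without a number. The expectation is therefore uncertain. A moderate loss is estimated, with the step of a 3.8-fold higher number from compound 1 to compound 4 (0.57 log units; beyond the scatter) expected to be smaller than the loss seen for compound 3. Compound 4 is thus expected to give about 30 nM in this assay, within a range from 6 nM to 150 nM.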

Compound 4, half-maximal effective concentration: 23000 nM
Compound 4: middle estimate off by 770-fold (2.88 log units), on the low side; the whole stated range lies below it.
By their numbers in this assay, from the lowest: compound 1; then compound 3; then compound 4.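

Among these compounds, this result gives the first size for a change on the amide-type nitrogen itself. In this assay, oxetan-3-yl in place of ethyl brings a 2900-fold higher number from compound 1 to compound 4 (3.46 log units; beyond the scatter) and that is a very large loss, although a number can still be reported. Among the compounds shown here, the only earlier number for a change to compound 1 came from an aromatic carbon, with a 30-fold higher number from compound 1 to compound 3 (1.47 log units; beyond the scatter) as the result, while the "not active" entry for compound 2 concerned a different place and carried no size. Nothing measured here accounts for the loss at the nitrogen.

The new group differs from ethyl in three ways at once, since it has more heavy atoms, a ring and an oxygen, and the compounds shown cannot separate these. Methyl, a longer chain such as propyl, or an all-carbon ring such as cyclobutyl on this nitrogen would help show which of these differences goes with the loss, and whether any other group here can match the value of compound 1.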